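Lengthening the Amine Chain: An Expected Gain

The source may hold more compounds than are shown below. What is called first, only, known or untested is meant among the compounds shown, and "the series" means these compounds.

Compound 1 `CN(C)CCNc1nc(N/N=C/c2ccc(Cl)cc2)nc2ccccc12` and compound 2 `CN(C)CCCNc1nc(N/N=C/c2ccc(Cl)cc2)nc2ccccc12` share one core and differ only by (dimethylamino)methyl in place of dimethylamino on a saturated chain carbon, two bonds along the chain from a nitrogen on an aromatic ring. In a functional assay on NCI-H460 cells (Homo sapiens) for cytotoxicity, read by MTT assay, with a stated time of 72 h (on this read-out lower numbers stand for stronger inhibition and higher numbers for weaker inhibition), compound 1 gives 3250 nM, while compound 2 gives 1490 nM; the step of a 2.2-fold lower number from compound 1 to compound 2 (0.34 log units; beyond the scatter). Compound 3 `CN(C)CCNc1nc(N/N=C/c2nccn2Cc2ccccc2)nc2ccccc12` carries a different aromatic part on the hydrazone; the difference between the cores of compound 1 and compound 3 is not broken down here. In this assay compound 3 gives 9650 nM, the highest of the three numbers. Compound 4 `CN(C)CCCNc1nc(N/N=C/c2nccn2Cc2ccccc2)nc2ccccc12` is related to compound 3 by (dimethylamino)methyl in place of dimethylamino on a saturated chain carbon, two bonds along the chain from a nitrogen on an aromatic ring, the same change, at the same place, as that between compound 1 and compound 2. A step of similar size is expected for compound 4, a 2.1-fold lower number from compound 3 to compound 4 (0.33 log units; beyond the scatter), resting on the earlier step of a 2.2-fold lower number from compound 1 to compound 2 (0.34 log units; beyond the scatter). For compound 4 in this assay the estimate is 4500 nM, expected to lie between 2000 nM and 10000 nM.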

Compound 4, half-maximal inhibitory concentration: 4670 nM
Beside the measured number, compound 4's estimate is 1.0-fold (0.02 log units) below it; the measured number falls inside the stated range.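

Replacing the (2-(dimethylamino)ethyl)amino chain with (3-(dimethylamino)propyl)amino on the core of compound 3 gives a 2.1-fold lower number from compound 3 to compound 4 (0.32 log units; beyond the scatter) in this assay. The change therefore carries over from one core to the other with its size preserved: the same change on two cores in this assay, a 2.2-fold lower number (0.34 log units; beyond the scatter) from compound 1 to compound 2 and a 2.1-fold lower number (0.32 log units; beyond the scatter) from compound 3 to compound 4, 1.1-fold (0.02 log units) apart, within the scatter of two such steps. For the compounds shown here, this rests on only two pairs, one change and one cell line, so it shows that the step transfers between these two cores but neither explains the step nor establishes that it would hold on any other core.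

As far as these compounds go, it remains open whether a longer chain would extend the same trend. From the compounds shown here alone, it is also open whether a morpholine in place of dimethylamino would keep the step on either core.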